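Removing the ring nitrogen's methyl: an expected small change

The source may hold more compounds than are shown below. What is called first, only, known or untested is meant among the compounds shown, and "the series" means these compounds.

In an ADME assay on cells (Hepatocyte, Homo sapiens) for cytotoxicity, read by MTT assay, with a stated time of 90 min, tested at 200 uM (a higher number here means a weaker effect of the compound at the concentration tested, a lower number a stronger effect), compound 3 `Cc1c(C)c2c(c(C)c1CCCCCCN)CCC(C)(COc1ccc(/C=C3\SC(=O)N(C)C3=O)cc1)O2` gives 82.7%. For the measured compounds named here, compound 2 `Cc1c(C)c2c(c(C)c1CCCCCCNC(=O)OCc1ccccc1)CCC(C)(COc1ccc(/C=C3\SC(=O)NC3=O)cc1)O2` gives 80.3%, a number that cannot be told apart from compound 3's, while compound 1 `Cc1c(C)c2c(c(C)c1OC(=O)CCCCCCCN)CCC(C)(COc1ccc(/C=C3\SC(=O)N(C)C3=O)cc1)O2` gives 54.4%, clearly lower; the one measured step, a number 28.3 percentage points higher from compound 1 to compound 3 (beyond the scatter), concerns a different part of the core. Compound 4 `Cc1c(C)c2c(c(C)c1CCCCCCN)CCC(C)(COc1ccc(/C=C3\SC(=O)NC3=O)cc1)O2` differs from compound 3 by hydrogen in place of methyl on an amide-type nitrogen in a ring. Going by the values given here, no measured pair isolates this change: compound 2 and compound 3 differ at this nitrogen but also elsewhere, so their values carry no clean lesson. Without direct evidence, the expectation is a step of a number 2.7 percentage points lower from compound 3 to compound 4 (within the scatter), that is, none beyond the scatter. Compound 4 is therefore estimated at 80%, with a range from 62% to 95%.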

Compound 4, a percentage reported as activity, at one concentration (the size of the read-out at that concentration, not a potency): 79.9%
Beside the measured number, compound 4's estimate is 0.1 percentage points above it; the measured number falls inside the stated range.
By their numbers in this assay, from the lowest: compound 1; then compounds 4, 2 and 3 (each within the scatter of the next).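

In this assay, hydrogen in place of methyl on the amide-type nitrogen in a ring gives a number 2.8 percentage points lower from compound 3 to compound 4 (within the scatter), so this first clean pair shows no readable effect of that methyl. Hydrogen in place of benzyloxycarbonyl on the amine nitrogen gives a number 0.4 percentage points lower from compound 2 to compound 4 (within the scatter), so that change also cannot be read as an effect on this number. No measurement at hand explains either result. Open, on these data alone, is whether a larger group on the ring nitrogen, such as benzyl, or a carboxylic acid in place of the amine, would stay within the scatter.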